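This account rests on a few compounds, and the source may have more. Where it says the series, first, only, none or still open, it means among the compounds named here.

Measured compounds:
compound 1 `COc1ccc(-c2nc(C)c(C(=O)CSc3nc(-c4ccc(Cl)cc4)c(C#N)c(=O)[nH]3)s2)cc1` — 92.7%
compound 2 `COc1ccc(-c2nc(C)c(C(=O)CSc3nc(-c4cccc(OC)c4)c(C#N)c(=O)[nH]3)s2)cc1` — 66.7%
compound 3 `Cc1nc(-c2ccc(Cl)cc2)sc1C(=O)CSc1nc(-c2ccc(Cl)cc2)c(C#N)c(=O)[nH]1` — 98.4%

The three compounds were tested in a functional assay on U-87MG ATCC cells for antiproliferative activity against U-87 MG (Homo sapiens), read by MTT assay, with a stated time of 48 h, tested at 10 uM; a higher number here means a weaker effect of the compound at the concentration tested, a lower number a stronger effect. Compound 4 `COc1cccc(-c2nc(SCC(=O)c3sc(-c4ccc(Cl)cc4)nc3C)[nH]c(=O)c2C#N)c1` has not yet been run in this assay.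

Among the compounds with values here, the one exchange already measured is that between compound 1 and compound 2: 3-methoxyphenyl in place of 4-chlorophenyl on an aromatic carbon. Within the data shown here, its step was a number 26 percentage points lower from compound 1 to compound 2 (beyond the scatter), a modest drop in the read-out that lies beyond the scatter, so this change is the only one among the measured pairs that moved the number clearly.

The cores of compound 1 and compound 3 differ as follows: chloro in place of methoxy on an aromatic carbon. Across this difference the read-out hardly moved, a number 5.7 percentage points higher from compound 1 to compound 3 (within the scatter), a step within the scatter. Compound 3 and compound 1 therefore read alike, and neither can be called stronger or weaker than the other on these data.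

Compound 4 is reached from compound 3 by 3-methoxyphenyl in place of 4-chlorophenyl on an aromatic carbon. The surroundings of the place are described in the same words as for the change from compound 1 to compound 2, so this is the same change, now on the core of compound 3. Because the core difference a number 5.7 percentage points higher from compound 1 to compound 3 (within the scatter) stayed within the scatter, the yardstick for the new exchange is the measured step of a number 26 percentage points lower from compound 1 to compound 2 (beyond the scatter). A step of about that size is what is expected as a number 25.4 percentage points lower from compound 3 to compound 4 (beyond the scatter). On that basis compound 4 is expected to give 73%, with the estimate spanning 55% to 92%. Two pairs are a thin basis, and a larger or smaller step would not be surprising.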

Compound 4, a percentage reported as activity, at one concentration (the size of the read-out at that concentration, not a potency): 89.7%
Beside the measured number, compound 4's estimate is 16.7 percentage points below it; the range from low to high includes it.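

In this assay, 3-methoxyphenyl in place of 4-chlorophenyl gives a number 8.7 percentage points lower from compound 3 to compound 4 (within the scatter), so the clear step seen on the core of compound 1 does not repeat on the core of compound 3, and the two steps disagree: the same change on two cores in this assay, a number 26 percentage points lower (beyond the scatter) from compound 1 to compound 2 and a number 8.7 percentage points lower (within the scatter) from compound 3 to compound 4, 17.3 percentage points apart, beyond the scatter of two such steps. Read the other way, chloro in place of methoxy gives a number 23 percentage points higher from compound 2 to compound 4 (beyond the scatter), and this exchange also depends on its surroundings: the same change on two cores in this assay, a number 5.7 percentage points higher (within the scatter) from compound 1 to compound 3 and a number 23 percentage points higher (beyond the scatter) from compound 2 to compound 4, 17.3 percentage points apart, beyond the scatter of two such steps. In these four compounds, a step measured on one core therefore cannot simply be added to another core, but a single set of four compounds shows neither the cause nor whether this holds for the wider series.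

The compounds shown leave open whether the dependence on the core is confined to the pairing of methoxy and chloro groups or also appears with other substituents, such as an amine or a carboxylic acid on either phenyl ring. They also leave open whether a longer chain in place of the methyl group on the shared core would change the size of these steps, and a read-out at one concentration gives no potency for any of the compounds.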